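From a Limit Back Toward Measurable Modulation

The source may hold more compounds than are shown below. What is called first, only, known or untested is meant among the compounds shown, and "the series" means these compounds.

Compound 3 `O=C(c1cccc(F)c1)N1CC(c2nc(-c3cccc(Cl)c3)no2)C1` is the weakest point on this series by what has been measured. In an assay on HEK293 cells for positive allosteric modulation of metabotropic glutamate receptor 5 (Homo sapiens), read by FLIPR (on this read-out lower numbers stand for an effect already at smaller amounts and higher numbers for an effect only at larger amounts of compound), compound 3 gives > 10000 nM, which is a limit of the assay and not a number (the limit of > 10000 nM in this assay, at which 1 of the 3 values shown sits). Two measured compounds share its core. Compound 1 `O=C(N1CCC(F)CC1)N1CC(c2nc(-c3cccc(Cl)c3)no2)C1` gives 990 nM in this assay, and compound 2 `CC1CCC(C(=O)N2CC(c3nc(-c4cccc(Cl)c4)no3)C2)CC1` gives 1500 nM. The steps toward compound 3 were an at least 10-fold higher number from compound 1 to compound 3 (1.00 log units; beyond the scatter) and an at least 6.6-fold higher number from compound 2 to compound 3 (0.82 log units; beyond the scatter).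

Compound 4 `CC1CCN(C(=O)N2CC(c3nc(-c4cccc(Cl)c4)no3)C2)CC1` is not yet measured. The change from compound 3 is 4-methylpiperidin-1-yl in place of 3-fluorophenyl on a carbonyl carbon. The entering group is a saturated ring like those of compound 1 and compound 2, so the two steps toward compound 3 are read in reverse: a lower number is expected in this assay, back into the region of compound 1 and compound 2. The step is estimated as an at least 8.3-fold lower number from compound 3 to compound 4 (0.92 log units; beyond the scatter). Compound 4 is therefore expected to give 1200 nM in this assay, with a range from 450 nM to 4000 nM.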

Compound 4, half-maximal effective concentration: 865 nM
The estimate for compound 4 lay 1.4-fold (0.14 log units) above the measured number; measured number inside the range.
By their numbers in this assay, from the lowest: compounds 4, 1 and 2 (each within the scatter of the next). At a limit, above all of these: compound 3.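

Setting 4-methylpiperidin-1-yl in place of 3-fluorophenyl on the carbonyl carbon gives an at least 11-fold lower number from compound 3 to compound 4 (1.06 log units; beyond the scatter) in this assay, so a second kind of exchange, with the same count of heavy atoms on each side, now separates the aromatic group of compound 3 from a saturated ring. Compound 3 stays a limit of the assay and not a number, so this step is only a bound: the limit of > 10000 nM in this assay, at which 1 of the 4 values shown sits.

Among the saturated rings, neither a 1.7-fold lower number from compound 2 to compound 4 (0.24 log units; within the scatter) nor a 1.1-fold lower number from compound 1 to compound 4 (0.06 log units; within the scatter) leaves the scatter, so at this position neither exchange, of 4-methylcyclohexyl or of fluoro for methyl, separates these compounds.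

The compounds shown leave open whether phenyl without its fluorine would stay at such a limit, or whether fluorine alone carries the difference. They also leave open how an open chain such as n-butyl or a morpholine ring would behave at this carbonyl carbon.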